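Aryl in Place of Isopropyl on a Sulfonyl Proline Scaffold

A few compounds are considered here, and "the series" means these few. Any claim that something is new, unique, unknown or untested is made for them only; others in the source may bear on it.

Of the compounds shown here, three have been measured in an assay on RPMI-8866 cells for inhibition of integrin alpha-4/beta-1 (Homo sapiens); on this read-out lower numbers stand for stronger inhibition and higher numbers for weaker inhibition. Compound 1 `CC(C)[C@@H](CC(=O)O)NC(=O)[C@@H]1CCCN1S(=O)(=O)c1cc(Cl)cc(Cl)c1` gives 8.9 nM in this assay, the highest of the three numbers, so it is the weakest inhibitor among them. Compound 2 `O=C(O)C[C@@H](NC(=O)[C@@H]1CCN1S(=O)(=O)c1cc(Cl)cc(Cl)c1)c1ccc(OC2CC2)cc1` gives 0.31 nM, and compound 3 `O=C(O)C[C@@H](NC(=O)[C@@H]1CCN1S(=O)(=O)c1cc(Cl)cc(Cl)c1)c1ccc(OC2CCCC2)cc1` gives 0.5 nM; the step of a 1.6-fold higher number from compound 2 to compound 3 (0.21 log units; within the scatter) shows that exchanging one cycloalkyl ether for another leaves the number essentially unchanged. Both of these compounds carry an aryl ether on the carbon next to the acid-bearing chain, where compound 1 carries isopropyl, but their core also differs from that of compound 1, so no single measured step isolates the aryl change.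

Compound 4 `CCOc1ccc([C@@H](CC(=O)O)NC(=O)[C@@H]2CCCN2S(=O)(=O)c2cc(Cl)cc(Cl)c2)cc1` differs from compound 1 in one place: 4-ethoxyphenyl in place of isopropyl on a saturated chain carbon bound to an amide-type nitrogen and a saturated chain carbon. The closest guide is the gap between compound 1 and the two aryl-bearing compounds, which is beyond the scatter in both cases, although part of that gap may come from the core. On that basis a substantial fall in the number is expected, smaller than the full gap to compound 2, giving an estimated step of an 11-fold lower number from compound 1 to compound 4 (1.05 log units; beyond the scatter). Compound 4 is therefore expected to give about 0.8 nM in this assay, within a range of 0.2 nM to 3.5 nM.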

Compound 4, half-maximal inhibitory concentration: 0.27 nM
Beside the measured number, compound 4's estimate is 3.0-fold (0.47 log units) above it; low and high end bracket the measured number.
By their numbers in this assay, from the lowest: compounds 4, 2 and 3 (each within the scatter of the next); then compound 1.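

In this assay, putting 4-ethoxyphenyl in place of isopropyl on a saturated chain carbon bound to an amide-type nitrogen and a saturated chain carbon gives a 33-fold lower number from compound 1 to compound 4 (1.52 log units; beyond the scatter) and is beyond the scatter. Among the compounds shown here, this is the first reading of the aryl change on its own, since the earlier compounds bearing an aryl ether also differ from compound 1 in the core, and the whole step here arises with the core of compound 1 left unchanged. This position alone can thereby take the number in this series from the value of compound 1 down to that of compound 4 at 0.27 nM without any change of core, although no measurement at hand says what lies behind a step of this size.

The change brings in an aromatic ring and an ether oxygen together, so this one step cannot divide its size between them, and a plain phenyl group or a phenyl group carrying an amine would be needed to tell them apart. Going by these compounds, how a longer alkoxy chain on the ring would read on this core also remains open.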